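A few compounds are considered here, and "the series" means these few. Any claim that something is new, unique, unknown or untested is made for them only; others in the source may bear on it.

Compound 1 `COC(=O)c1c(C)[nH]c(C)c1C(=O)c1ccccc1` gives, in a functional assay with Cavia porcellus as the target (a higher number here means that more compound is needed for the effect, a lower number that less compound is needed), 21900 nM. Compound 2 `COC(=O)c1c(C)[nH]c(C)c1C(=O)c1ccccc1C` differs from it by a methyl in place of hydrogen on an aromatic carbon and gives 9470 nM, so that there is a 2.3-fold lower number from compound 1 to compound 2 (0.36 log units; beyond the scatter). Compound 3 `COC(=O)c1c[nH]cc1C(=O)c1ccccc1Cc1ccccc1` gives 2100 nM, the lowest of the three numbers; the difference between its core and that of compound 1 is not broken down here.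

Compound 4 `COC(=O)c1c(C(=O)c2ccccc2Cc2ccccc2)c[nH]c1C`, not yet measured, carries relative to compound 3 a (methyl in place of hydrogen on an aromatic carbon). Among the measured compounds shown here, this is the same kind of change as the one between compound 1 and compound 2, but not the same: there the methyl sits on a six-membered aromatic ring of carbon only, ortho to a large group, whereas here it sits on a five-membered aromatic ring with 1 nitrogen, next to the ring nitrogen and next to the ring atom that bears a methoxycarbonyl group. The earlier step of this kind was modest, and on that basis a modest step, a 1.3-fold lower number from compound 3 to compound 4 (0.12 log units; within the scatter), is expected in this assay, though the differing place leaves this uncertain. For compound 4 the estimate in this assay is 1600 nM, between 500 nM and 5000 nM.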

Compound 4, half-maximal effective concentration: 460 nM
Compound 4: middle estimate off by 3.5-fold (0.54 log units), on the high side; the measured number lies below the stated range.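

In this assay, the methyl in place of hydrogen on an aromatic carbon again goes with a lower number, with a 4.6-fold lower number from compound 3 to compound 4 (0.66 log units; beyond the scatter). The two steps point the same way, and the gap between their sizes gives no sign that the two cores respond differently to this change: the same change on two cores in this assay, a 2.3-fold lower number (0.36 log units; beyond the scatter) from compound 1 to compound 2 and a 4.6-fold lower number (0.66 log units; beyond the scatter) from compound 3 to compound 4, 2.0-fold (0.30 log units) apart, within the scatter of two such steps. Among the compounds shown here, this rests on only two pairs, with the methyl on a six-membered aromatic ring of carbon only in compound 2 and on a five-membered aromatic ring with 1 nitrogen in compound 4, so it does not show that the step would carry over to other places or other cores, and it does not explain why the number falls.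

The compounds shown leave open whether a larger group in the same place as the methyl of compound 4, such as an ethyl or a longer chain, would go the same way. They also leave open whether an amine or a carboxylic acid there would keep the lower number.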